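The compounds below may be only part of what the source reports. "The series", "measured", "known", "first", "only" and "open" are said of these compounds alone.

In an ADME assay on microsomes from liver (Homo sapiens) for metabolic stability (on this read-out higher numbers stand for fast clearance and lower numbers for slow clearance), compound 1 `CN1C(=O)C2=C(C1=O)N(CC(=O)Nc1ccc(-c3ccccn3)cc1)CCC2` gives 28 mL.min-1.g-1. Compound 2 `Cc1ccc(-c2ccc(NC(=O)CN3CCCC4=C3C(=O)N(C3CC3)C4=O)nn2)cn1`, which carries a different core and a different aromatic part, gives 23 mL.min-1.g-1 in this assay; the two numbers lie within the usual scatter of each other, so compound 1 cannot be set apart from compound 2 on this read-out. Compound 3 `CN1C(=O)C2=C(C1=O)N(CC(=O)Nc1ccc(-c3nccs3)cc1)CCC2` has not yet been measured. It differs from compound 1 in one place: 1,3-thiazol-2-yl in place of pyridin-2-yl on an aromatic carbon. Among the measured compounds shown here, no measured pair shows this change, so its effect is unknown. The step from compound 1 to compound 3 is expected to stay within the scatter, a 1.1-fold higher number from compound 1 to compound 3 (0.03 log units; within the scatter), with compound 3 estimated at 30 mL.min-1.g-1, between 14 mL.min-1.g-1 and 60 mL.min-1.g-1.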

Compound 3, intrinsic clearance in microsomes: 24 mL.min-1.g-1
For compound 3 the middle estimate is 1.3-fold (0.10 log units) above the measured one; the range from low to high includes it.
By their numbers in this assay, from the lowest: compounds 2, 3 and 1 (each within the scatter of the next).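

In this assay, 1,3-thiazol-2-yl in place of pyridin-2-yl gives a 1.2-fold lower number from compound 1 to compound 3 (0.07 log units; within the scatter), so this first pair differing in one place does not separate the two groups on this read-out. At this place, para to a large group, a five-membered aromatic ring with 2 hetero atoms and a six-membered aromatic ring with 1 hetero atom therefore cannot be told apart here. Nothing available bears on the reason for this result. Still open, on these data alone, is whether a non-aromatic group at this place, such as morpholine or a carboxylic acid, would give a clearly different clearance. Also open, as far as these compounds go, is whether the same change would behave alike on the core of compound 2.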